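The compounds below may be only part of what the source reports. "The series", "measured", "known", "first", "only" and "open" are said of these compounds alone.

Compound 1 `CN(C)c1ccc(C2CC(c3ccc(-n4cncn4)cc3)=NN2C(=O)c2ccc(C(F)(F)F)cc2)cc1`: 7%
Compound 2 `CN(C)c1ccc(C2CC(c3ccc(-n4cncn4)cc3)=NN2S(C)(=O)=O)cc1`: 10.8%
Compound 3 `CN(C)c1ccc(C2CC(c3ccc(-n4ccnc4)cc3)=NN2C(=O)c2ccc(C(F)(F)F)cc2)cc1`: 28%

All three were tested in a functional assay on HCC1806 cells (Homo sapiens) for inhibition, read by sulforhodamine B assay, tested at 10 uM; a higher number here means more inhibition at the concentration tested (going by the name of the read-out), a lower number less inhibition. Compound 3 stands highest of the three in this assay; its step from compound 1 is a number 21 percentage points higher from compound 1 to compound 3 (beyond the scatter), and compound 2 lies beyond the scatter below it as well. The step of a number 3.8 percentage points higher from compound 1 to compound 2 (within the scatter), by contrast, lies within the scatter.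

Compound 4 `CN(C)c1ccc(C2CC(c3ccc(-n4ccnc4)cc3)=NN2S(C)(=O)=O)cc1` has not yet been measured in this assay. It differs from compound 3 by methylsulfonyl in place of (4-(trifluoromethyl)phenyl)carbonyl on an amine nitrogen in a ring. The same kind of change is seen between compound 1 and compound 2, namely (methylsulfonyl in place of (4-(trifluoromethyl)phenyl)carbonyl on an amine nitrogen in a ring), where the step was a number 3.8 percentage points higher from compound 1 to compound 2 (within the scatter). The two cores differ by 1H-imidazol-1-yl in place of 1H-1,2,4-triazol-1-yl on an aromatic carbon. The surroundings of the place are not identical: in compound 3 the ring atom two ring bonds away bears a 4-(1H-imidazol-1-yl)phenyl group, whereas in compound 1 it bears a 4-(1H-1,2,4-triazol-1-yl)phenyl group, so the change is the same kind of change, not the same one.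

Among the measured compounds shown here, because a number 3.8 percentage points higher from compound 1 to compound 2 (within the scatter) lay within the scatter, the step from compound 3 to compound 4 is expected to be similarly small, a number 2 percentage points higher from compound 3 to compound 4 (within the scatter), although only one earlier instance of this change is available, so the expectation is loose. Compound 4 is therefore estimated to give 30% in this assay, with a likely range from 15% to 45%.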

Compound 4, a percentage reported as inhibition, at one concentration (the size of the read-out at that concentration, not a potency): 11.3%
Compound 4: the middle estimate sits 18.7 percentage points above what was measured; the measured number lies below the stated range.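

On the core of compound 3, methylsulfonyl in place of (4-(trifluoromethyl)phenyl)carbonyl gave a number 16.7 percentage points lower from compound 3 to compound 4 (beyond the scatter) in this assay, so this change did not carry over from the core of compound 1 with the same size: the same change on two cores in this assay, a number 3.8 percentage points higher (within the scatter) from compound 1 to compound 2 and a number 16.7 percentage points lower (beyond the scatter) from compound 3 to compound 4, 20.5 percentage points apart, beyond the scatter of two such steps. With methylsulfonyl on the amine nitrogen in the ring, 1H-imidazol-1-yl in place of 1H-1,2,4-triazol-1-yl gave only a number 0.5 percentage points higher from compound 2 to compound 4 (within the scatter), so the effect of this second change also depended on its surroundings: the same change on two cores in this assay, a number 21 percentage points higher (beyond the scatter) from compound 1 to compound 3 and a number 0.5 percentage points higher (within the scatter) from compound 2 to compound 4, 20.5 percentage points apart, beyond the scatter of two such steps. Among these four compounds, the two changes therefore do not add up independently, and only compound 3, which combines 1H-imidazol-1-yl with (4-(trifluoromethyl)phenyl)carbonyl, stands clear of the rest, but this rests on one pair of steps at a single concentration and does not show why the steps differ or whether the same holds in other compounds.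

The compounds shown leave open whether 1H-imidazol-1-yl would give a similar rise with other groups on the ring nitrogen, such as acetyl or phenylsulfonyl. They also leave open what a morpholine ring or a methoxy group would do in place of the dimethylamino group of the 4-(dimethylamino)phenyl group.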